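Changing the Aryl Group on the Triazole: Compound 4

This account rests on a few compounds, and the source may have more. Where it says the series, first, only, none or still open, it means among the compounds named here.

Compound 1, `CCc1ccccc1-n1nncc1CN1C(=O)C2(C(C#N)=C(N)Oc3c(N)cc4nc5ccccc5nc4c32)c2ccccc21`, in a functional assay on A549 cells (Homo sapiens) for antiproliferative activity, read by MTT assay, with a stated time of 48 h; a higher number here means a weaker inhibitor, a lower number a stronger inhibitor: compound 1 gives 24600 nM.
Compound 3, `N#CC1=C(N)Oc2c(N)cc3nc4ccccc4nc3c2C12C(=O)N(Cc1cnnn1-c1ccccc1Br)c1ccccc12`, in this assay: compound 3 gives 27400 nM.
Compound 2, `N#CC1=C(N)Oc2c(N)cc3nc4ccccc4nc3c2C12C(=O)N(Cc1cnnn1-c1ccc(F)cc1)c1ccccc12`, in this assay: compound 2 gives only a limit of the assay, > 50000 nM.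

Among the two actual numbers, compound 3 shows the highest, with compound 1 nearest: a 1.1-fold higher number from compound 1 to compound 3 (0.05 log units; within the scatter). The third value, that of compound 2, is a limit and not a number.

Compound 4, `CCOc1ccc(-n2nncc2CN2C(=O)C3(C(C#N)=C(N)Oc4c(N)cc5nc6ccccc6nc5c43)c3ccccc32)cc1`, differs from compound 3 in one place: 4-ethoxyphenyl in place of 2-bromophenyl on an aromatic nitrogen. Among the measured compounds shown here, two measured steps bear on this. Going to the 4-fluorophenyl gave an at least 2.0-fold higher number from compound 1 to compound 2 (0.30 log units; that floor lies within the scatter), while leaving it again gave an at least 1.8-fold lower number from compound 2 to compound 3 (0.26 log units; that floor lies within the scatter). The incoming 4-ethoxyphenyl shares its substitution pattern with the 4-fluorophenyl of compound 2, so a higher number in this assay, possibly again a limit, is expected, although both measured steps rest on a limit and only reach the edge of the scatter.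

Compound 4 is therefore expected to give about 45000 nM, within a range from 20000 nM to 100000 nM, which means an expected 1.6-fold higher number from compound 3 to compound 4 (0.22 log units; within the scatter).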

Compound 4, half-maximal inhibitory concentration: > 50000 nM
Compound 4: no number, only a limit; the forecaster's own chance of this, stated with the estimate: 40%; middle value at least 1.1-fold (0.04 log units) away from the limit.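

In this assay, the 4-ethoxyphenyl of compound 4 gives only a limit of the assay, not a number, as the 4-fluorophenyl of compound 2 did, so two different groups on this aromatic nitrogen now end at that limit. The readable steps are an at least 1.8-fold higher number from compound 3 to compound 4 (0.26 log units; that floor lies within the scatter) and an at least 2.0-fold higher number from compound 1 to compound 4 (0.30 log units; that floor lies within the scatter), so the separation from the 2-bromophenyl and 2-ethylphenyl compounds is suggested, not established. The step from compound 2 to compound 4 cannot be read because both compounds sit at the same limit: the limit of > 50000 nM in this assay, at which 2 of the 4 values shown sit.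

Still open, on these data alone, is whether this reading follows the substituent's place on the phenyl ring or the substituent itself, which a 2-ethoxyphenyl or a 4-bromophenyl group could separate. As far as these compounds go, how an amine or a carboxylic acid on that ring would read is also open.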